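Diisopropylamino in place of acetoxy on compound 1

The source may hold more compounds than are shown below. What is called first, only, known or untested is meant among the compounds shown, and "the series" means these compounds.

In a functional assay on SW480 cells (Homo sapiens) for antiproliferative activity, read by MTT assay, with a stated time of 48 h (a lower number here means a stronger inhibitor, a higher number a weaker inhibitor), compound 1 (`CC(=O)OC/C1=C/C[C@](C)(CCC=C(C)C)/C=C/[C@@H](OC(=O)C=C(C)C)[C@](C)(O)/C=C/C1=O`) gives 2950 nM. Compound 3 (`C=C1/C=C/C(=O)/C(CO)=C\C[C@](C)(CCC=C(C)C)/C=C/[C@H]1OC(=O)C=C(C)C`) gives 2970 nM, within the scatter of compound 1, while compound 2 (`CO[C@]1(C)/C=C/C(=O)/C(CO)=C\C[C@](C)(CCC=C(C)C)/C=C/[C@H]1OC(=O)C=C(C)C`) gives a higher number, 15200 nM, beyond the scatter. Compound 4 (`CC(C)=CCC[C@]1(C)/C=C/[C@@H](OC(=O)C=C(C)C)[C@](C)(O)/C=C/C(=O)/C(CN(C(C)C)C(C)C)=C\C1`) carries diisopropylamino in place of acetoxy on a saturated chain carbon bound to a double-bonded ring carbon. Among the measured compounds shown here, no measured pair isolates this change, so its direction remains open. No step beyond the scatter is expected in this assay, and the estimated 1.0-fold higher number from compound 1 to compound 4 (0.01 log units; within the scatter) is small against a wide range. For compound 4 the expected value is 3000 nM, with an estimated range of 900 nM to 12000 nM.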

Compound 4, half-maximal inhibitory concentration: 750 nM
Compound 4: middle estimate off by 4.0-fold (0.60 log units), on the high side; the whole stated range lies above it.
By their numbers in this assay, from the lowest: compound 4; then compounds 1 and 3 (each within the scatter of the next); then compound 2.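

In this assay, among the compounds shown here, diisopropylamino in place of acetoxy gives a 3.9-fold lower number from compound 1 to compound 4 (0.59 log units; beyond the scatter), the first single-place comparison. This saturated chain carbon bound to a double-bonded ring carbon therefore accepts an amine carrying more heavy atoms than acetoxy, and the number falls rather than rises. No available evidence accounts for the gain. On these data alone, whether a smaller amine such as dimethylamino, or a ring amine such as piperidine, would match compound 4 remains open. Also open, as far as these compounds go, is whether the same change would lower the numbers on the cores of compound 2 and compound 3.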